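Swapping the ring on the ether oxygen for a piperidine

The source may hold more compounds than are shown below. What is called first, only, known or untested is meant among the compounds shown, and "the series" means these compounds.

Of the compounds shown here, three sharing one core have been measured in an assay for inhibition of serine/threonine-protein kinase Sgk1 (Homo sapiens), with stated times of 30 min and 60 min, in the presence of a further agent that is not named here; a higher number here means a weaker inhibitor, a lower number a stronger inhibitor. Compound 1 `CCOc1nc(-c2ccc(NS(=O)(=O)c3cc(Cl)ccc3F)cc2)nc2[nH]nc(C)c12` gives 183 nM. Compound 2 `Cc1n[nH]c2nc(-c3ccc(NS(=O)(=O)c4cc(Cl)ccc4F)cc3)nc(OCC3(CN)COC3)c12` gives 1 nM. Compound 3 `Cc1n[nH]c2nc(-c3ccc(NS(=O)(=O)c4cc(Cl)ccc4F)cc3)nc(OC3CCC(=O)CC3)c12` gives 18 nM, which places it second highest of the three, between the other two: a 10-fold lower number from compound 1 to compound 3 (1.01 log units; beyond the scatter) and an 18-fold higher number from compound 2 to compound 3 (1.26 log units; beyond the scatter). Compound 4 `Cc1n[nH]c2nc(-c3ccc(NS(=O)(=O)c4cc(Cl)ccc4F)cc3)nc(OC3CC(C)(C)NC(C)(C)C3)c12` changes compound 3 in one place: 2,2,6,6-tetramethylpiperidin-4-yl in place of 4-oxocyclohexyl on an oxygen on an aromatic ring. For the measured compounds named here, two measured steps bear on this. Replacing the ethyl of compound 1 by a ring gave a 10-fold lower number from compound 1 to compound 3 (1.01 log units; beyond the scatter), and the group that carries a nitrogen gave a 180-fold lower number from compound 1 to compound 2 (2.26 log units; beyond the scatter), the largest step seen. Compound 4 combines both features, a ring and a nitrogen, so the expectation for it in this assay is a step of about a 4.5-fold lower number from compound 3 to compound 4 (0.65 log units; beyond the scatter), towards a lower number, though a piperidine nitrogen is not the aminomethyl of compound 2 and the size is uncertain. For compound 4 the estimated value is 4 nM, expected to fall between 1 nM and 20 nM.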

Compound 4, half-maximal inhibitory concentration: 4 nM
The estimate for compound 4 equals the measured number at the digits printed; measured number inside the range.
By their numbers in this assay, from the lowest: compound 2; then compound 4; then compound 3; then compound 1.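

In this assay, a ring carrying a nitrogen also works on this ether oxygen: the 2,2,6,6-tetramethylpiperidin-4-yl group in place of 4-oxocyclohexyl gives a stronger inhibitor (a 4.5-fold lower number from compound 3 to compound 4 (0.65 log units; beyond the scatter)). Measured against the small ethyl group, the same ring gives a much larger gain (a 46-fold lower number from compound 1 to compound 4 (1.66 log units; beyond the scatter)), yet the nitrogen-bearing group of compound 2 remains ahead (a 4.0-fold higher number from compound 2 to compound 4 (0.60 log units; beyond the scatter)), so having a nitrogen in this group does not alone match compound 2. Nothing available here explains these differences.

Compound 4 differs from compound 3 in both the ring nitrogen and the four methyl groups, so the contribution of each stays unresolved. A plain piperidin-4-yl group, without the methyl groups, would separate the two, and a carboxylic acid on the ring would test a quite different group here.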